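The source may report more compounds than this note shows. Statements on the series, on what has been measured and on what is new or still open speak of the compounds shown alone.

Measured so far:
Compound 1 `N#CC1=C(N)N(c2ccc(S(N)(=O)=O)cc2)C2=C(CCCC2)C1c1ccccc1O`: in a functional assay on Ehrlich cells (Mus musculus) for cytotoxicity, read by trypan blue exclusion, with a stated time of 2 h, tested at 50 ug/mL (a higher number here means a stronger effect of the compound at the concentration tested, a lower number a weaker effect), compound 1 gives 50%.
Compound 2 `N#CC1=C(N)N(c2ccc(S(N)(=O)=O)cc2)C2=C(CCCC2)C1c1ccc(O)cc1`: in this assay compound 2 gives 60%.
Compound 3 `N#CC1=C(N)N(c2ccc(S(N)(=O)=O)cc2)C2=C(CCCC2)C1c1cccc([N+](=O)[O-])c1`: in this assay compound 3 gives 2%.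

Compound 3 stands lowest of the three numbers in this assay. The step is a number 48 percentage points lower from compound 1 to compound 3 (beyond the scatter), and likewise a number 58 percentage points lower from compound 2 to compound 3 (beyond the scatter), both beyond the scatter. Compound 1 and compound 2 themselves differ only by a number 10 percentage points higher from compound 1 to compound 2 (within the scatter), within the scatter.

Compound 4 `N#CC1=C(N)N(c2ccc(S(N)(=O)=O)cc2)C2=C(CCCC2)C1c1ccc(Cl)c(Cl)c1` arises from compound 3 by 3,4-dichlorophenyl in place of 3-nitrophenyl on a saturated ring carbon. Among the measured compounds shown here, no measured step changes the aryl group on that saturated ring carbon into a 3,4-dichlorophenyl, so the two steps into compound 3 are the only guide: both show that the 3-nitrophenyl sits far below the hydroxyphenyl groups, but they say nothing direct about the new group. The account therefore expects that compound 4 recovers part of the lost activity in this assay, with a step of a number 28 percentage points higher from compound 3 to compound 4 (beyond the scatter) expected, though with wide uncertainty. Compound 4 is estimated at 30%, between 5% and 60%.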

Compound 4, a percentage reported as activity, at one concentration (the size of the read-out at that concentration, not a potency): 50%
For compound 4 the middle estimate is 20 percentage points below the measured one; the measured number falls inside the stated range.
By their numbers in this assay, from the lowest: compound 3; then compounds 1, 4 and 2 (each within the scatter of the next).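

The aryl group on this saturated ring carbon does not need a hydroxyl to hold its activity in this assay: the 3,4-dichlorophenyl group, with no hydrogen-bond donors or acceptors, gives a number 48 percentage points higher from compound 3 to compound 4 (beyond the scatter) and brings compound 4 level with both hydroxyphenyl compounds, with no change at the digits printed from compound 1 to compound 4 (within the scatter) and a number 10 percentage points lower from compound 2 to compound 4 (within the scatter) as the remaining steps. The low value is therefore specific to the 3-nitrophenyl of compound 3, the only one of the four that goes against this, and not to the loss of the hydroxyl. Nothing available here explains why that one group stands apart.

The compounds shown leave open whether one chlorine alone would serve as well as two. They also leave open how a methoxy, an amine or a carboxylic acid on this phenyl ring would read.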